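Sigma ligand series: amine terminus change at the six-bond position

The compounds below may be only part of what the source reports. "The series", "measured", "known", "first", "only" and "open" are said of these compounds alone.

Three compounds share a core carrying an aminoalkoxy chain. In an assay on isolated protein (Cavia porcellus) with Sigma non-opioid intracellular receptor 1 (Homo sapiens) as the target, read by radioligand binding (on this read-out higher numbers stand for weaker inhibition and lower numbers for stronger inhibition), compound 1 `CN(C)CCCCOc1ccc2oc(-c3ccccc3)cc(=O)c2c1` gives 720 nM, compound 2 `CN(C)CCCCCCCOc1ccc2oc(-c3ccccc3)cc(=O)c2c1` gives 165 nM and compound 3 `O=c1cc(-c2ccccc2)oc2ccc(OCCCCCCN3CCCC(O)C3)cc12` gives 86 nM. Compound 3 holds the lowest number of the three: its step from compound 2 is a 1.9-fold lower number from compound 2 to compound 3 (0.28 log units; within the scatter), whereas from compound 1 it is an 8.4-fold lower number from compound 1 to compound 3 (0.92 log units; beyond the scatter). Compound 4 `CCOC(=O)C1CCN(CCCCCCOc2ccc3oc(-c4ccccc4)cc(=O)c3c2)CC1` differs from compound 3 by 4-(ethoxycarbonyl)piperidin-1-yl in place of 3-hydroxypiperidin-1-yl on a saturated chain carbon, six bonds along the chain from an oxygen on an aromatic ring. Among the compounds with values here, no measured step exchanges one substituted piperidine for another; the closest precedent is a 1.9-fold lower number from compound 2 to compound 3 (0.28 log units; within the scatter), where changing the amine terminus at the same chain position moved the number little, while a 4.4-fold lower number from compound 1 to compound 2 (0.64 log units; beyond the scatter) concerned chain length, not the terminus. On this basis a step no larger than the scatter is expected in this assay, with the value of compound 4 estimated at 110 nM (range 30 nM to 400 nM), which means an expected 1.3-fold higher number from compound 3 to compound 4 (0.11 log units; within the scatter).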

Compound 4, half-maximal inhibitory concentration: 164 nM
Compound 4: the middle estimate sits 1.5-fold (0.17 log units) below what was measured, and the stated range covers the measured number.
By their numbers in this assay, from the lowest: compounds 3, 4 and 2 (each within the scatter of the next); then compound 1.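

Exchanging one substituted piperidine for another at this chain carbon, six bonds along the chain from an oxygen on an aromatic ring, gives (a 1.9-fold higher number from compound 3 to compound 4 (0.28 log units; within the scatter)) in this assay. The change brings a larger group with no hydrogen-bond donor, yet the number stays within the scatter, and the dimethylamino-ended comparison gives the same picture (a 1.0-fold lower number from compound 2 to compound 4 (0.00 log units; within the scatter)). Across these three termini, the hydroxyl of 3-hydroxypiperidin-1-yl is thus not needed for a number in this range, while nothing measured here bears on the reason for this. Open, going by these compounds, is how the unsubstituted piperidin-1-yl group or a carboxylic acid in place of the ethyl ester would read at this position. Also open, on these data alone, is whether 4-(ethoxycarbonyl)piperidin-1-yl would keep this number on a shorter or longer chain.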